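A Ring Methyl Added to a Compound at the Limit

The source may report more compounds than this note shows. Statements on the series, on what has been measured and on what is new or still open speak of the compounds shown alone.

In a functional assay on MCF7 cells (Homo sapiens) for antiproliferative activity, read by MTT assay (a higher number here means a weaker inhibitor, a lower number a stronger inhibitor), compound 1 (`CCCCCCCCCCCCCCCc1cc(=O)c2c(O)c(C)c(OCOC)cc2o1`) has no number, only a limit of > 67200 nM as its reading. Compound 2 (`CCCCC/C=C\C/C=C\CCCCCCCc1cc(=O)c2c(O)c(C)c(OCOC)cc2o1`) also gives only a limit, > 67200 nM as well. The change of chain shows a step that the two limits leave unreadable from compound 1 to compound 2 and tells nothing of size. Compound 3 (`CCCCCCCCCCCCCCCc1cc(=O)c2c(O)c(C)c(O)cc2o1`) alone gives a number, 43200 nM in this reading. Hydrogen in place of methoxymethyl on the oxygen gives an at least 1.5-fold lower number from compound 1 to compound 3 (0.19 log units; that floor lies within the scatter) as the only other step.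

Compound 4 (`CCCCCCCCCCCCCCCc1cc(=O)c2c(O)c(C)c(OCOC)c(C)c2o1`) differs from compound 1 as follows: methyl in place of hydrogen on an aromatic carbon. Neither measured step touches this aromatic carbon, so neither gives a direct size for the change. Compound 4 keeps the methoxymethoxy group, and both compounds carrying it sit at the limit of > 67200 nM in this assay, at which 2 of the 3 values shown sit, in this reading. No step beyond the scatter is therefore expected in this assay, and no direction can be given, with a further limit the likeliest report. The estimated step is a step that the limit leaves unreadable from compound 1 to compound 4 in size. For compound 4 the expected value is 75000 nM, with an estimated range from 40000 nM to 140000 nM in this reading.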

Compound 4, half-maximal inhibitory concentration: > 67200 nM
Compound 4: a limit, no number; the forecaster's own chance of this, stated with the estimate: 75%; the middle value does not contradict the limit.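

In this assay, among these compounds, compound 4 gives only a limit, > 67200 nM as its reading, and compound 1 also gives only a limit, so no step between the two can be read: the limit of > 67200 nM in this assay, at which 3 of the 4 values shown sit.

The compounds shown leave open whether methyl in place of hydrogen on this aromatic carbon changes the reading at all, and in which direction.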